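Methoxy added ortho to methoxy on compound 1

A few compounds are considered here, and "the series" means these few. Any claim that something is new, unique, unknown or untested is made for them only; others in the source may bear on it.

Measured so far in a functional assay on NCI-H322M cells (Homo sapiens) for inhibition, read by sulforhodamine B assay, with a stated time of 48 h; on this read-out lower numbers stand for stronger inhibition of growth and higher numbers for weaker inhibition of growth:
- compound 1 `COc1ccc(-c2cc(/C=C/C(=O)c3ccc(N)cc3)[nH]n2)cc1`: 1840 nM
- compound 2 `COc1ccc(C(=O)/C=C/c2cc(-c3cc(OC)c(OC)c(OC)c3)n[nH]2)cc1`: 1920 nM

Compound 1 holds the lower of the two numbers in this assay, but compound 2 sits within the scatter of it, so the two cannot be ordered on these data. Going by the values given here, no step between measured compounds that differ in a single place is available, so there is no internal yardstick for a small substituent change.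

Compound 3 `COc1ccc(-c2cc(/C=C/C(=O)c3ccc(N)cc3)[nH]n2)cc1OC` differs from compound 1 by methoxy in place of hydrogen on an aromatic carbon. With no measured step of this kind in the series, the expectation is a small change in this assay, in either direction, most likely not beyond the scatter, with a slight lean toward a lower number. For compound 3 the estimated step is a 1.2-fold lower number from compound 1 to compound 3 (0.09 log units; within the scatter). Compound 3 is thus expected to give 1500 nM, within a range of 600 nM to 4000 nM.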

Compound 3, concentration for 50% growth inhibition: 4340 nM
Compound 3: middle estimate off by 2.9-fold (0.46 log units), on the low side; measured number outside the range, above it.
By their numbers in this assay, from the lowest: compounds 1 and 2 (each within the scatter of the next); then compound 3.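

In this assay, going by these compounds alone, methoxy in place of hydrogen on this aromatic carbon, ortho to a methoxy group and meta to a large group, gives a 2.4-fold higher number from compound 1 to compound 3 (0.37 log units; beyond the scatter) as the first single-place step. This position is therefore not indifferent to substitution: here the added methoxy goes with weaker inhibition of growth, by a modest step beyond the scatter. Nothing at hand bears on what lies behind this step.

As far as these compounds go, whether the step is particular to methoxy or extends to other groups at this carbon remains open; fluorine, a hydroxyl or an ethoxy there would test this. Also open, from the compounds shown here alone, is whether the same change gives a step of similar size and direction on other members.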